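This account rests on a few compounds, and the source may have more. Where it says the series, first, only, none or still open, it means among the compounds named here.

Working notes on the series. Four compounds share one core and differ only in the amino acid residue: compound 1 `O=C(CN(c1nc(Cl)nc2[nH]cnc12)C1CC1)N[C@@H](CO)C(=O)OCc1ccccc1`, compound 2 `C[C@@H](O)[C@H](NC(=O)CN(c1nc(Cl)nc2[nH]cnc12)C1CC1)C(=O)OCc1ccccc1`, compound 3 `N=C(N)NCCC[C@H](NC(=O)CN(c1nc(Cl)nc2[nH]cnc12)C1CC1)C(=O)OCc1ccccc1` and compound 4 `O=C(CN(c1nc(Cl)nc2[nH]cnc12)C1CC1)N[C@@H](CCC(=O)OCc1ccccc1)C(=O)OCc1ccccc1`. In a functional assay on the whole organism (Tail, strain ICR) with Mus musculus as the target, in the tail flick test, with a stated time of 150 min, at a dose of 25 umol/kg by the oral route (on this read-out higher numbers stand for a stronger effect at the one dose given and lower numbers for a weaker effect), compound 1 gives 27.9%, compound 2 gives 12.8% and compound 3 gives 6.12%. Compound 3 stands lowest of the three numbers; its nearest neighbour is compound 2, higher by a margin within the scatter, and its furthest is compound 1, higher by a margin beyond the scatter.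

The change to compound 4 is a group of 10 heavy atoms (8 carbon, 2 oxygen; one six-membered aromatic ring of carbon only) in place of a group of 5 heavy atoms (2 carbon, 3 nitrogen; no ring), on a saturated chain carbon, three bonds along the chain from an amide-type nitrogen and a carbonyl carbon. The measured steps that touch the same varied part of the structure are a number 15.1 percentage points lower from compound 1 to compound 2 (beyond the scatter), a number 21.8 percentage points lower from compound 1 to compound 3 (beyond the scatter) and a number 6.7 percentage points lower from compound 2 to compound 3 (within the scatter). Every enlargement of this varied part away from the oxygen of compound 1 went with a lower or an unchanged number, and the group of 5 heavy atoms now leaving is the one whose entry accompanied the largest of these drops. Among the measured compounds shown here, no measured step tests a benzyloxycarbonyl at this place, so the bearing is indirect. The expectation is a small rise from compound 3, of a size not clearly beyond the scatter: for compound 4 the estimate in this assay is 14%, with a range from 3% to 32%, which means an expected step of a number 7.9 percentage points higher from compound 3 to compound 4 (within the scatter).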

Compound 4, a percentage reported as activity, at one dose (the size of the read-out at that dose, not a potency): 44.5%
For compound 4 the middle estimate is 30.5 percentage points below the measured one; measured number outside the range, above it.
By their numbers in this assay, from the lowest: compounds 3 and 2 (each within the scatter of the next); then compound 1; then compound 4.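

In this assay the side chain at this position is not limited to falling numbers: benzyloxycarbonyl in place of the group of 5 heavy atoms gives a number 38.4 percentage points higher from compound 3 to compound 4 (beyond the scatter), and 2-(benzyloxycarbonyl)ethyl in place of 1-hydroxyethyl gives a number 31.7 percentage points higher from compound 2 to compound 4 (beyond the scatter). The small side chain of compound 1 is also not the upper mark of the series, since (benzyloxycarbonyl)methyl in place of hydroxy gives a number 16.6 percentage points higher from compound 1 to compound 4 (beyond the scatter), so compound 4 goes against the reading, drawn from compounds 1, 2 and 3, that enlarging this part lowers the number. Nothing at hand accounts for this reversal.

The compounds shown leave open which part of the new side chain goes with the higher number: the aromatic ring, the ester or the chain length. A free carboxylic acid at the same place, a plain benzyl group and a longer chain ending in the same benzyl ester would separate these parts, and a dose series in this assay would show whether the order of the compounds holds beyond the one dose given.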